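The source may report more compounds than this note shows. Statements on the series, on what has been measured and on what is new or still open speak of the compounds shown alone.

Measured so far in a functional assay on DU-145 cells (Homo sapiens) for cytotoxicity, read by MTT assay; on this read-out higher numbers stand for weaker inhibition and lower numbers for stronger inhibition:
compound 1 `CC[C@](C)(O)CC(=O)O[C@H](CC=C(C)C)C1=CC(=O)c2c(O)ccc(O)c2C1=O`, compound 1 gives 20500 nM
compound 2 `CC(C)=CC[C@@H](OC(=O)CCO)C1=CC(=O)c2c(O)ccc(O)c2C1=O`, compound 2 gives 55300 nM
compound 3 `CCCC(C)(O)CC(=O)O[C@H](CC=C(C)C)C1=CC(=O)c2c(O)ccc(O)c2C1=O`, compound 3 gives 75000 nM

Compound 3 has the highest number of the three; compound 2 lies within the scatter of it, and compound 1 is the only one clearly lower (a 3.7-fold higher number from compound 1 to compound 3 (0.56 log units; beyond the scatter)). Compound 4 `CCC(O)CO[C@H](CC=C(C)C)C1=CC(=O)c2c(O)ccc(O)c2C1=O` differs from compound 3 at the oxygen on the saturated carbon: 2-hydroxybutyl in place of (2-hydroxy-2-methylpentyl)carbonyl on an oxygen on a saturated carbon. Going by the values given here, no measured step touches this oxygen; the nearest are the chain changes a 1.4-fold higher number from compound 2 to compound 3 (0.13 log units; within the scatter) and a 3.7-fold higher number from compound 1 to compound 3 (0.56 log units; beyond the scatter), which show shortening the chain leaving the number unchanged or lower. The step of a 1.5-fold lower number from compound 3 to compound 4 (0.18 log units; within the scatter) is therefore expected to be small. For compound 4 a value of about 50000 nM is expected, between 15000 nM and 150000 nM.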

Compound 4, half-maximal inhibitory concentration: 16400 nM
Estimate against measurement, compound 4: 3.0-fold (0.48 log units) above; low and high end bracket the measured number.
By their numbers in this assay, from the lowest: compounds 4 and 1 (each within the scatter of the next); then compounds 2 and 3 (each within the scatter of the next).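

In this assay, 2-hydroxybutyl on this oxygen in place of (2-hydroxy-2-methylpentyl)carbonyl gives a step beyond the scatter (a 4.6-fold lower number from compound 3 to compound 4 (0.66 log units; beyond the scatter)), and in place of (2-hydroxyethyl)carbonyl it does likewise (a 3.4-fold lower number from compound 2 to compound 4 (0.53 log units; beyond the scatter)). Compound 1 goes against this lowering: in place of (2-hydroxy-2-methylbutyl)carbonyl, the step stays within the scatter (a 1.3-fold lower number from compound 1 to compound 4 (0.10 log units; within the scatter)). Among these four compounds, then, the carbonyl on this oxygen is not needed to reach the level of compound 1.

From the compounds shown here alone, whether a 2-aminobutyl chain or a longer 2-hydroxyhexyl chain on this oxygen would keep that level remains open. No measurement on hand accounts for these steps.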